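Shifting the ring substituent from trifluoromethyl to fluoro

A few compounds are considered here, and "the series" means these few. Any claim that something is new, unique, unknown or untested is made for them only; others in the source may bear on it.

Among the compounds with values here, compound 3 `CC1=CCCC(C)(C)C1/C=C/C(=O)/C=C/c1ccccc1C(F)(F)F` stands at the highest of the three numbers so far in a functional assay on LNCaP cells (Homo sapiens) for cytotoxicity, read by MTT assay, with a stated time of 72 h; a higher number here means a weaker inhibitor, a lower number a stronger inhibitor: compound 3 gives 22600 nM. Compound 1 `CC1=C(/C=C/C(=O)/C=C/c2ccccc2F)C(C)(C)CCC1` carries a core different from that of compound 3. In this assay compound 1 gives 10700 nM, and compound 2 `CC1=C(/C=C/C(=O)/C=C/c2ccc(F)cc2)C(C)(C)CCC1` gives 7300 nM. Within the data shown here, the one measured step, a 1.5-fold lower number from compound 1 to compound 2 (0.17 log units; within the scatter), moves the fluoro substituent from one aromatic carbon to another and lies within the scatter.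

Compound 4 `CC1=CCCC(C)(C)C1/C=C/C(=O)/C=C/c1ccccc1F` keeps the core of compound 3 and changes only the aromatic substituent: fluoro in place of trifluoromethyl on an aromatic carbon, ortho to a large group. Among the measured compounds shown here, no measured step replaces trifluoromethyl with fluoro, so the measured step from compound 1 to compound 2 bears on it only by showing that the fluorophenyl compounds sit together at the lower end of the numbers. Compound 4 carries the same fluoro substituent as compound 1, whose value of 10700 nM is the closest guide available, and the number for compound 4 is therefore expected to come in lower than that of compound 3 by a 1.9-fold lower number from compound 3 to compound 4 (0.27 log units; within the scatter). On that basis compound 4 is estimated at 12000 nM in this assay, with a range from 5000 nM to 30000 nM.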

Compound 4, half-maximal inhibitory concentration: 1600 nM
Compound 4: middle estimate off by 7.5-fold (0.88 log units), on the high side, outside the stated range (below it).
By their numbers in this assay, from the lowest: compound 4; then compounds 2 and 1 (each within the scatter of the next); then compound 3.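

On the shared core, this aromatic carbon proves sensitive to which group it carries: fluoro in place of trifluoromethyl gives a 14-fold lower number from compound 3 to compound 4 (1.15 log units; beyond the scatter) in this assay. Within the data shown here, the earlier compounds could not show this, as their only step, a 1.5-fold lower number from compound 1 to compound 2 (0.17 log units; within the scatter), moves the fluoro substituent to another aromatic carbon without replacing it, and that step lies within the scatter. Nothing available here accounts for the size of the change from trifluoromethyl, with 4 heavy atoms, to fluoro, with 1 heavy atom.

The compounds shown leave open how chloro, methyl, methoxy or a nitrile on this same aromatic carbon would read in this assay, and so whether the low number belongs to fluoro alone or would extend to other small groups. Going by these compounds, it also remains open whether the exchange of trifluoromethyl for fluoro would give a step of similar size on the core of compound 1, and how fluoro on the other aromatic carbon, as in compound 2, would read on the core of compound 4.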